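Bromo to trifluoromethyl: an untested step from compound 1

This account rests on a few compounds, and the source may have more. Where it says the series, first, only, none or still open, it means among the compounds named here.

Measured compounds in a functional assay on PC-9 cells (Homo sapiens) for inhibition, read by MTT assay, with a stated time of 48 h, tested at 10 uM; a lower number here means less inhibition, a higher number more inhibition at the concentration tested (going by the name of the read-out):
compound 1, `COc1ccc(Br)cc1Nc1cc(NC(=O)Nc2c(Cl)cccc2Cl)ncn1`, gives 69%
compound 2, `COc1cc(NC(=O)Nc2cc(Nc3cc(Br)ccc3OC)ncn2)cc(OC)c1`, gives 82.5%
compound 3, `COc1cc(Br)ccc1Nc1cc(NC(=O)Nc2c(Cl)cccc2Cl)ncn1`, gives 90.5%

Compound 1 stands lowest of the three numbers. The step of a number 13.5 percentage points higher from compound 1 to compound 2 (beyond the scatter) and the step of a number 21.5 percentage points higher from compound 1 to compound 3 (beyond the scatter) both lead upward from it, yet neither alters the bromo group. Compound 4, `COc1ccc(C(F)(F)F)cc1Nc1cc(NC(=O)Nc2c(Cl)cccc2Cl)ncn1`, differs from compound 1 by trifluoromethyl in place of bromo on an aromatic carbon. Among the measured compounds shown here, no measured pair changes that position, so the two known steps offer only a loose guide to its direction. The change is therefore expected to shift the number by a number 3 percentage points higher from compound 1 to compound 4 (within the scatter), a movement that may well stay within the scatter. Compound 4 is estimated at 72%, with a range from 55% to 88%.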

Compound 4, a percentage reported as inhibition, at one concentration (the size of the read-out at that concentration, not a potency): 89%
Estimate against measurement, compound 4: 17 percentage points below; measured number above the stated range.
By their numbers in this assay, from the lowest: compound 1; then compounds 2, 4 and 3 (each within the scatter of the next).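

In this assay trifluoromethyl in place of bromo gives a number 20 percentage points higher from compound 1 to compound 4 (beyond the scatter) and so shows that this aromatic carbon, para to a methoxy group, is itself a place where a change moves the number. The earlier steps shown here, both made elsewhere on compound 1, could not show this. Nothing available explains the rise. Going by these compounds, whether chloro, a nitrile or an amine on this carbon would move the number the same way stays open, as does whether trifluoromethyl would give a similar step with the 3,5-dimethoxyphenyl of compound 2.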